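Cytotoxicity shift on swapping the aryl group

A few compounds are considered here, and "the series" means these few. Any claim that something is new, unique, unknown or untested is made for them only; others in the source may bear on it.

compound 1 `O=C(CSc1nnnn1-c1cccc2ccccc12)N/N=C/c1ccco1` — > 330000 nM
compound 2 `O=C(CSc1nnnn1-c1cccc2ccccc12)N/N=C/c1ccccc1F` — >= 118000 nM
compound 3 `COc1ccc(O)c(/C=N/NC(=O)CSc2nnnn2-c2cccc3ccccc23)c1` — 4510 nM

In an ADME assay on MT4 cells (Homo sapiens) for cytotoxicity, read by MTT assay (on this read-out lower numbers stand for higher toxicity in this test and higher numbers for lower toxicity in this test), compound 1 gives only a limit of the assay, > 330000 nM. Compound 2 also gives a limit rather than a number, >= 118000 nM. Compound 3 is the only one of the three with a measured number, 4510 nM, and it stands as the lowest value shown: the two changes leading to it, an at least 73-fold lower number from compound 1 to compound 3 (1.86 log units; beyond the scatter) and an at least 26-fold lower number from compound 2 to compound 3 (1.41 log units; beyond the scatter), were both large drops.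

Compound 4 `O=C(CSc1nnnn1-c1cccc2ccccc12)N/N=C/c1ccc(O)cc1` has not yet been measured. It differs from compound 3 by a single change: 4-hydroxyphenyl in place of 2-hydroxy-5-methoxyphenyl on a carbon with a double bond to nitrogen. The two measured steps show that replacing a 2-hydroxy-5-methoxyphenyl group with another aryl group moved the number strongly upward in reverse, but 4-hydroxyphenyl itself has not been tested, so the size of the step is uncertain. The number for compound 4 is therefore expected to rise again in this assay, an 8.9-fold higher number from compound 3 to compound 4 (0.95 log units; beyond the scatter), with a real chance that only a limit is reported. The estimate for compound 4 is 40000 nM, in a range from 8000 nM to 330000 nM.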

Compound 4, half-maximal cytotoxic concentration: > 309000 nM
Compound 4: no number, only a limit; the forecaster's own chance of this, stated with the estimate: 35%; at least 7.7-fold (0.88 log units) between middle value and limit.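

In this assay compound 4 gives no number, only a limit: the limit of > 309000 nM in this assay, at which 1 of the 4 values shown sits. The change to 4-hydroxyphenyl brings an at least 68-fold higher number from compound 3 to compound 4 (1.83 log units; beyond the scatter), so the presence of a hydroxy group on the ring does not by itself go with the low number of compound 3. Of the four groups shown on this carbon with a double bond to nitrogen, only 2-hydroxy-5-methoxyphenyl gives a measured number, while furan-2-yl, 2-fluorophenyl and 4-hydroxyphenyl all end in limits, and the steps among those three cannot be read.

The step from compound 3 to compound 4 removes the methoxy group and also changes where the hydroxy group sits, so the compounds shown cannot separate these two changes. From the compounds shown here alone, what a 2-hydroxyphenyl group or a 3-methoxyphenyl group would give at this place stays open.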